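Halogenated N-aryl variants of the pyridopyrimidinone amide series

The compounds below may be only part of what the source reports. "The series", "measured", "known", "first", "only" and "open" are said of these compounds alone.

The shared core carries an amide linking a fluorinated diaryl ether to a fused bicyclic lactam whose ring nitrogen bears an aryl group; the series varies that aryl group. Compound 1 `Cn1ccc2c(Oc3ccc(NC(=O)c4cc5cccnc5n(-c5ccccc5)c4=O)cc3F)ccnc21` carries an unsubstituted phenyl there. Within the data shown here, in a functional assay on NCI-H460 cells (Homo sapiens) for antiproliferative activity, read by MTT assay, with a stated time of 72 h (on this read-out lower numbers stand for stronger inhibition and higher numbers for weaker inhibition), compound 1 gives 550 nM, the only number reported for the set. Compound 2 `COc1ccc(-n2c(=O)c(C(=O)Nc3ccc(Oc4ccnc5c4ccn5C)c(F)c3)cc3cccnc32)cc1` carries a 4-methoxyphenyl; in this assay compound 2 gives "not determined" (no result reported), so no result was reported for it. Compound 3 `Cn1ccc2c(Oc3ccc(NC(=O)c4cc5cccnc5n(-c5ccc(F)c(Cl)c5)c4=O)cc3F)ccnc21` carries a 3-chloro-4-fluorophenyl, and in this assay compound 3 gives "not determined" (no result reported), so compound 3 also stands without a number, one of two entries in that position.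

Compound 4 `Cn1ccc2c(Oc3ccc(NC(=O)c4cc5cccnc5n(-c5ccc(Br)cc5F)c4=O)cc3F)ccnc21` differs from compound 3 in one place: 4-bromo-2-fluorophenyl in place of 3-chloro-4-fluorophenyl on an aromatic nitrogen. Among the measured compounds shown here, no measured pair in the set differs in a single place, so no step size is available for this change, and the only anchor is compound 1 with 550 nM. Halogen patterns on this aryl group are expected to move the value little beyond the scatter relative to compound 1. Compound 4 is therefore estimated at 600 nM in this assay, within a range of 150 nM to 3000 nM.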

Compound 4, half-maximal inhibitory concentration: 3150 nM
Beside the measured number, compound 4's estimate is 5.3-fold (0.72 log units) below it; the whole stated range lies below it.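

In this assay, the aryl group on the aromatic nitrogen proves sensitive to substitution: 4-bromo-2-fluorophenyl in place of phenyl gives a 5.7-fold higher number from compound 1 to compound 4 (0.76 log units; beyond the scatter), a weaker result for this halogen pattern than for the unsubstituted phenyl. Among these compounds, this is the only step readable at this position, as compound 2 and compound 3 have no number, and the change from 3-chloro-4-fluorophenyl to 4-bromo-2-fluorophenyl cannot be read. No supporting data bear on why the number rises.

The compounds shown leave open whether bromine alone or fluorine alone on the phenyl moves the number as far as the two together, and how the 4-methoxyphenyl of compound 2 and the 3-chloro-4-fluorophenyl of compound 3 compare with phenyl. Also open, from the compounds shown here alone, is how a group of another kind on this ring, such as an amine or a carboxylic acid, would read in this assay.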